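Trifluoromethylphenyl in Place of Methoxyphenyl on the Thiourea

The source may hold more compounds than are shown below. What is called first, only, known or untested is meant among the compounds shown, and "the series" means these compounds.

In a functional assay on HL-60 cells (Homo sapiens) for antiproliferative activity, with a stated time of 24 h (a higher number here means a weaker inhibitor, a lower number a stronger inhibitor), compound 2 `COc1ccccc1NC(=S)N1CCc2c(sc(NC(=O)c3ccccc3Cl)c2C(N)=O)C1` gives 40900 nM, the highest of the two numbers in hand. Compound 1 `NC(=O)c1c(NC(=O)c2ccccc2Cl)sc2c1CCN(C(=S)Nc1ccccc1Br)C2` gives 9090 nM. Going by the values given here, the single step available, a 4.5-fold higher number from compound 1 to compound 2 (0.65 log units; beyond the scatter), shows that the aromatic group on the amide-type nitrogen shifts the read-out by a modest amount. Compound 3 `NC(=O)c1c(NC(=O)c2ccccc2Cl)sc2c1CCN(C(=S)Nc1ccc(C(F)(F)F)cc1)C2` differs from compound 2 by 4-(trifluoromethyl)phenyl in place of 2-methoxyphenyl on an amide-type nitrogen. Among the compounds with values here, no measured step covers this exact exchange, so its direction is uncertain. Compound 3 is expected to move back toward the stronger of the two numbers, an estimated step of a 2.7-fold lower number from compound 2 to compound 3 (0.44 log units; beyond the scatter). The estimate for compound 3 is 15000 nM, with a range from 4000 nM to 60000 nM.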

Compound 3, half-maximal inhibitory concentration: 7590 nM
Compound 3: middle estimate off by 2.0-fold (0.30 log units), on the high side; low and high end bracket the measured number.
By their numbers in this assay, from the lowest: compounds 3 and 1 (each within the scatter of the next); then compound 2.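

Replacing 2-methoxyphenyl with 4-(trifluoromethyl)phenyl on the amide-type nitrogen gives a 5.4-fold lower number from compound 2 to compound 3 (0.73 log units; beyond the scatter) in this assay and so shows that compound 2 is not simply the level for any group other than 2-bromophenyl. The comparison with 2-bromophenyl gives a 1.2-fold lower number from compound 1 to compound 3 (0.08 log units; within the scatter) and so does not separate these two groups at this position. Nothing measured here gives a reason for either step.

As far as these compounds go, whether the methoxy group or its place on the ring sets compound 2 apart remains open, for both differ in the step to compound 3. Also open, from the compounds shown here alone, is how this nitrogen would tolerate an unsubstituted phenyl, or a phenyl carrying an amine or a carboxylic acid.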